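Aryl Swap on the Exocyclic Arm: Hydroxyphenyl Variant

The compounds below may be only part of what the source reports. "The series", "measured", "known", "first", "only" and "open" are said of these compounds alone.

Compound 3 `COc1cc(/C=C2\CCC/C(=C\c3ccccc3F)C2=O)cc(OC)c1OC` gives 2200 nM in a functional assay on T84 cells (Homo sapiens) for antiproliferative activity, read by MTT assay, with a stated time of 72 h (on this read-out lower numbers stand for stronger inhibition and higher numbers for weaker inhibition), the lowest of the three numbers shown, though compound 1 `COc1cc(/C=C2\CCC/C(=C\c3ccc(F)c(F)c3)C2=O)cc(OC)c1OC` at 3500 nM and compound 2 `COc1cc(/C=C2\CCC/C(=C\c3ccccc3Br)C2=O)cc(OC)c1OC` at 4200 nM both sit within the scatter of it. Compound 4 `COc1cc(/C=C2\CCC/C(=C\c3cccc(O)c3)C2=O)cc(OC)c1OC` differs by 3-hydroxyphenyl in place of 2-fluorophenyl on a double-bonded chain carbon bound to a double-bonded ring carbon. Among the measured compounds shown here, the steps that bear on this are the aryl swaps at the same place, a 1.6-fold lower number from compound 1 to compound 3 (0.20 log units; within the scatter) and a 1.9-fold lower number from compound 2 to compound 3 (0.28 log units; within the scatter), together with a 1.2-fold higher number from compound 1 to compound 2 (0.08 log units; within the scatter); all three lie within the scatter. For the measured compounds named here, no measured step brings in a hydroxyl, so the hydrogen-bond donor and acceptor that enter are untested. Expected, therefore, is no step beyond the scatter, a 1.2-fold higher number from compound 3 to compound 4 (0.07 log units; within the scatter), with a wide range. Compound 4 is estimated at 2600 nM, between 1000 nM and 7000 nM.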

Compound 4, half-maximal inhibitory concentration: 6500 nM
For compound 4 the middle estimate is 2.5-fold (0.40 log units) below the measured one, and the stated range covers the measured number.
By their numbers in this assay, from the lowest: compounds 3, 1, 2 and 4 (each within the scatter of the next, the first and the last beyond it).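

Among the compounds shown here, at this place, on a double-bonded chain carbon bound to a double-bonded ring carbon, the 3-hydroxyphenyl group gives the first step beyond the scatter in this assay with a 3.0-fold higher number from compound 3 to compound 4 (0.47 log units; beyond the scatter) while the swaps among the halogen-bearing aryl groups all stayed within it. Against the other two partners the same swap stays within the scatter, with a 1.5-fold higher number from compound 2 to compound 4 (0.19 log units; within the scatter) and a 1.9-fold higher number from compound 1 to compound 4 (0.27 log units; within the scatter) so the separation holds only against 2-fluorophenyl. No measured evidence accounts for this step.

Open, from the compounds shown here alone, is whether the result follows the hydroxyl itself or the way the aryl group is substituted. A methoxy, an amine or a carboxylic acid on the same aryl ring would help separate those readings.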